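The compounds below may be only part of what the source reports. "The series", "measured", "known", "first", "only" and "open" are said of these compounds alone.

Working notes on the series. In a functional assay on EL4 cells (Mus musculus) for inhibition, tested at 100 uM (a higher number here means more inhibition at the concentration tested (going by the name of the read-out), a lower number less inhibition), compound 1 `OC[C@H]1OC(n2cnc3c(SCc4ccccc4)nccc32)[C@H](O)[C@@H]1O` gives 30%. Compound 2 `CN(C)c1nccc2c1ncn2C1O[C@H](CO)[C@@H](O)[C@H]1O` gives 10% in this assay, and compound 3 `[N-]=[N+]=Nc1nccc2c1ncn2[C@H]1C[C@H](O)[C@@H](CO)O1` gives 13%. Compound 2 therefore sits at the low end of the three numbers, but its gap to compound 3 is within the scatter, so no order between those two can be read; only compound 1 stands beyond the scatter above it. For the measured compounds named here, the one step measured between single-change neighbours is a number 20 percentage points lower from compound 1 to compound 2 (beyond the scatter), a drop that followed the exchange of benzylsulfanyl for dimethylamino.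

Compound 4 `CSc1nccc2c1ncn2C1O[C@H](CO)[C@@H](O)[C@H]1O` has not been measured. It differs from compound 2 by methylsulfanyl in place of dimethylamino on an aromatic carbon. Going by the values given here, the single measured step that bears on this is the one just described, since it also concerns the swap between dimethylamino and a sulfur-bearing group on the same aromatic carbon, here run the other way: dimethylamino leaves and a sulfanyl group enters. That step was modest but beyond the scatter, so a rise of similar or somewhat smaller size is expected, methylsulfanyl being a smaller group than benzylsulfanyl. Compound 4 is thus expected to give 22% in this assay, in the range 8% to 36%. The expected step is a number 12 percentage points higher from compound 2 to compound 4 (beyond the scatter).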

Compound 4, a percentage reported as inhibition, at one concentration (the size of the read-out at that concentration, not a potency): < 5%
Compound 4: only a limit was reported (the forecaster's own chance of this, stated with the estimate: 0%); at least 17 percentage points between middle value and limit.
By their numbers in this assay, from the lowest: compounds 2 and 3 (each within the scatter of the next); then compound 1. At a limit, below all of these: compound 4.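

In this assay compound 4 gives only a limit, not a number: the limit of < 5% in this assay, at which 1 of the 4 values shown sits.

Hydrogen in place of phenyl on the saturated chain carbon bound to the sulfur goes with a number at least 25 percentage points lower from compound 1 to compound 4 (beyond the scatter), so on this aromatic carbon next to the ring nitrogen a sulfur link alone does not preserve the read-out of compound 1, and the number goes with the full benzylsulfanyl group. Methylsulfanyl in place of dimethylamino goes with a number at least 5 percentage points lower from compound 2 to compound 4 (that floor lies within the scatter), so these two groups cannot be put in order at this position, and the earlier drop on going to dimethylamino can no longer be read simply as the loss of sulfur.

The compounds shown leave open whether the phenyl ring itself or merely a longer group on the sulfur carries the effect, which ethylsulfanyl or a longer alkyl chain on the same carbon would separate. They also leave open whether the sulfur link is needed at all, a question that benzylamino or benzyloxy at this carbon would address.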